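Cyclopentyl carbamate in place of methyl at the shared core

The source may hold more compounds than are shown below. What is called first, only, known or untested is meant among the compounds shown, and "the series" means these compounds.

Measured compounds:
compound 1, `CNC(=O)OC[C@H]1OC(n2cnc3c(NC4CCOC4)nc(Cl)nc32)[C@H](O)[C@@H]1O`, 96 nM
compound 2, `O[C@@H]1[C@@H](CO/C(S)=N/C2CCC2)OC(n2cnc3c(NC4CCOC4)ncnc32)[C@@H]1O`, 148 nM

Of the compounds shown here, two have been measured in an assay on DDT1 cells (Cricetulus griseus) for binding affinity to adenosine receptor A1 (Homo sapiens), read by radioligand binding; a lower number here means a stronger inhibitor, a higher number a weaker inhibitor. Compound 1 gives 96 nM, and compound 2 gives 148 nM; the gap between the two lies within the scatter of this assay, so neither can be set above the other. Compound 3, `O=C(NC1CCCC1)OC[C@H]1OC(n2cnc3c(NC4CCOC4)nc(Cl)nc32)[C@H](O)[C@@H]1O`, has not yet been measured. It differs from compound 1 in one place: cyclopentyl in place of methyl on an amide-type nitrogen. No step between measured compounds covers a change of this kind, so no direction is shown by the data. Compound 3 is expected to remain close to compound 1, with the step of a 1.3-fold higher number from compound 1 to compound 3 (0.10 log units; within the scatter) not exceeding the scatter by much in either direction. The estimate for compound 3 in this assay is 120 nM, within a range from 30 nM to 500 nM.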

Compound 3, inhibition constant: 226 nM
Compound 3: the middle estimate sits 1.9-fold (0.27 log units) below what was measured, within the range that was stated.
By their numbers in this assay, from the lowest: compounds 1, 2 and 3 (each within the scatter of the next, the first and the last beyond it).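

In this assay, cyclopentyl in place of methyl on an amide-type nitrogen gives a 2.4-fold higher number from compound 1 to compound 3 (0.37 log units; beyond the scatter) and so shows that this position is not indifferent to the group it carries, a point that compounds 1 and 2 could not settle. The step is modest, and compound 3, with its five-membered ring of carbon only, remains a measurable binder at this position. Nothing available here accounts for the step.

With only methyl and cyclopentyl on this nitrogen, the compounds shown cannot tell whether the number rises gradually with the size of the group or whether the ring itself matters. Where an ethyl, a cyclopropyl, a longer chain or a phenyl group would fall on this nitrogen remains open.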